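Turning One Stereocentre in a Phenylurea on Rice

The source may hold more compounds than are shown below. What is called first, only, known or untested is meant among the compounds shown, and "the series" means these compounds.

Compound 1 `C[C@H](NC(=O)Nc1cccc(F)c1)c1ccccc1` and compound 2 `C[C@@H](NC(=O)Nc1cc(F)ccc1F)c1ccccc1` have both been tested in an ADME assay on the whole organism with Oryza sativa as the target, tested at 1 uM; on this read-out lower numbers stand for a stronger effect and higher numbers for a weaker effect at the one concentration tested. In this assay compound 1 gives 94%, and compound 2 gives 100%. Going by the values given here, compound 2 thus stands at the top of the two numbers recorded so far, but its only neighbour, compound 1, sits within the usual scatter of it, so the two cannot be told apart on this read-out.

Compound 3 `C[C@H](NC(=O)Nc1cc(F)ccc1F)c1ccccc1` has not yet been measured. It differs from compound 2 as follows: the two compounds have the same atoms and bonds and differ only in configuration as drawn: 1 of 1 stereo elements differ; a stereocentre at a saturated chain carbon is drawn R in compound 2 and S in compound 3. Among the compounds with values here, no step between measured compounds involves this kind of change, so the data give no direct guide to how inverting the stereocentre moves the read-out. Because compound 2 gives 100% and compound 1 gives 94%, both already near the weak end of the scale, a step of no more than modest size is expected. Compound 3 is estimated to give 95%, within 80% to 105%. The step of a number 5 percentage points lower from compound 2 to compound 3 (within the scatter) is expected to stay within the scatter.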

Compound 3, a percentage reported as activity, at one concentration (the size of the read-out at that concentration, not a potency): 98%
Compound 3: middle estimate off by 3 percentage points, on the low side; the measured number falls inside the stated range.
By their numbers in this assay, from the lowest: compounds 1, 3 and 2 (each within the scatter of the next).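

In this assay, inverting the stereocentre at the saturated chain carbon, drawn R in compound 2 and S in compound 3, gives a number 2 percentage points lower from compound 2 to compound 3 (within the scatter), so this first direct test of the centre shows no difference that can be told from the usual variation between repeats. The second step now available, fluoro in place of hydrogen on an aromatic carbon, gives a number 4 percentage points higher from compound 1 to compound 3 (within the scatter), and so this change on the ring cannot be distinguished on this read-out either. The first of these steps isolates the stereocentre, and it can be read as a test of configuration alone on one ground: the fact that compounds 2 and 3 differ only in the configuration as drawn.

What the compounds shown leave open is whether the configuration at this centre would matter at all on a core carrying a different group, such as an amine, a carboxylic acid or a longer chain. With a single concentration on a single read-out, they also leave open whether the two configurations would separate under any other test conditions.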